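The compounds below may be only part of what the source reports. "The series", "measured", "known", "first", "only" and "open" are said of these compounds alone.

Compound 1 `CCOC(=O)Cn1ncc2c(Nc3ccc(NC(=O)CCl)cc3)ncnc21` gives 3.51 ug/mL in a functional assay on cells (Homo sapiens) for inhibition, read by MTT assay, with a stated time of 72 h; on this read-out lower numbers stand for stronger inhibition and higher numbers for weaker inhibition.
Compound 2 `O=C(O)Cn1ncc2c(Nc3ccc(NS(=O)(=O)c4ccc(Br)cc4)cc3)ncnc21` gives only a limit, > 64 ug/mL, in this assay.
Compound 3 `CC(=O)Nc1ccc(Nc2ncnc3c2cnn3CC(=O)O)cc1` likewise gives only a limit, > 64 ug/mL, in this assay.

Compound 2 thus stands at the limit of this assay with no number of its own, and since compound 3 shares that limit, the step that the two limits leave unreadable from compound 2 to compound 3 cannot be read because of the limit of > 64 ug/mL in this assay, at which 2 of the 3 values shown sit. Compound 4 `CCOC(=O)Cn1ncc2c(Nc3ccc(NS(=O)(=O)c4ccc(Br)cc4)cc3)ncnc21` carries the change (ethyl in place of hydrogen on an oxygen next to a carbonyl group). Among the compounds with values here, no measured step matches this change. Within the data shown here, the one value given as a number, that of compound 1, belongs to a compound bearing the ethoxycarbonyl group, whereas compound 2 and compound 3, which bear the carboxy group, both sit at the limit. Compound 4 is therefore expected to give a readable number, the step of an at least 3.2-fold lower number from compound 2 to compound 4 (0.50 log units; beyond the scatter) being expected though of uncertain size. Compound 4 is estimated at 20 ug/mL, between 4 ug/mL and 64 ug/mL.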

Compound 4, half-maximal inhibitory concentration: > 64 ug/mL
Compound 4: no number, only a limit (the forecaster's own chance of this, stated with the estimate: 40%); middle value at least 3.2-fold (0.50 log units) away from the limit.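

Ethyl in place of hydrogen on an oxygen next to a carbonyl group leaves compound 4 at the limit in this assay, so neither step between two limits can be read: the limit of > 64 ug/mL in this assay, at which 3 of the 4 values shown sit.

With ethoxycarbonyl kept, (4-bromophenyl)sulfonyl in place of (chloromethyl)carbonyl on a nitrogen on an aromatic ring gives an at least 18-fold higher number from compound 1 to compound 4 (1.26 log units; beyond the scatter), a large step. Ethoxycarbonyl alone therefore does not bring a readable number; of the compounds shown, only compound 1, with (chloromethyl)carbonyl, has one.

Open, going by these compounds, is whether (chloromethyl)carbonyl still gives a number alongside a carboxy group. Also open, on these data alone, is what a free amine would give on that aromatic ring.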